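The compounds below may be only part of what the source reports. "The series", "measured", "known", "first", "only" and "open" are said of these compounds alone.

Compound 1 `CCCCCCCCCCCCCCNC(=O)[C@@H](NS(=O)(=O)c1ccc2ccccc2c1)[C@@H](C)O` gives 9360 nM in a functional assay on SW-620 cells (Homo sapiens) for cytotoxicity, read by MTT assay, with a stated time of 48 h; a higher number here means a weaker inhibitor, a lower number a stronger inhibitor.
Compound 2 `CCCCCCCCCCCCCCCCCCNC(=O)[C@@H](NS(=O)(=O)c1cccs1)[C@@H](C)O` gives only a limit, > 200000 nM, in this assay.

Compound 2 therefore stands at the limit of > 200000 nM in this assay, at which 1 of the 2 values shown sits, and its true value is not known. Compound 3 `CCCCCCCCCCCCCCCCCCNC(=O)[C@@H](NS(=O)(=O)c1ccc2ccccc2c1)[C@@H](C)O` differs from compound 2 by naphthalen-2-yl in place of thiophen-2-yl on a sulfonyl sulfur. Among the measured compounds shown here, no measured step covers this change alone, since compound 1 and compound 2 differ in a second place as well, so the two values show only that compound 1 sits at a number and compound 2 at a limit. The change is expected to move compound 3 toward stronger inhibition in this assay, beyond the scatter, with the step estimated as an at least 10-fold lower number from compound 2 to compound 3 (1.00 log units; beyond the scatter). Compound 3 is expected near 20000 nM, within 5000 nM to 150000 nM.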

Compound 3, half-maximal inhibitory concentration: 24600 nM
The estimate for compound 3 lay 1.2-fold (0.09 log units) below the measured number; low and high end bracket the measured number.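

With the chain held the same, naphthalen-2-yl in place of thiophen-2-yl on a sulfonyl sulfur gives an at least 8.1-fold lower number from compound 2 to compound 3 (0.91 log units; beyond the scatter) in this assay. With naphthalen-2-yl held, butyl in place of hydrogen on a saturated chain carbon gives only a 2.6-fold higher number from compound 1 to compound 3 (0.42 log units; beyond the scatter). The size of the sulfonyl change remains a bound, as compound 2 gives a limit: the limit of > 200000 nM in this assay, at which 1 of the 3 values shown sits.

On these data alone, it remains open how a phenyl group on the sulfonyl sulfur would read. Also open, as far as these compounds go, is whether thiophen-2-yl on the shorter chain would give a number.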